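Ether side-chain variation on the shared core

The source may report more compounds than this note shows. Statements on the series, on what has been measured and on what is new or still open speak of the compounds shown alone.

Measured compounds:
compound 1 `CCOCCOc1cccc2ccc(N)nc12` gives > 2000 nM in an assay on cells with melanin-concentrating hormone receptor 1 (Homo sapiens) as the target, read by radioligand binding (a higher number here means a weaker inhibitor, a lower number a stronger inhibitor), a limit of the assay.
compound 2 `CC#CCCOc1cccc2ccc(N)nc12` gives > 2000 nM in this assay, a limit of the assay.
compound 3 `CC1CC1COc1cccc2ccc(N)nc12` gives 1640 nM in this assay.

Compound 3 is the only one of the three with a number; the other two sit at the limit of > 2000 nM in this assay, at which 2 of the 3 values shown sit. The measured steps are an at least 1.2-fold lower number from compound 1 to compound 3 (0.08 log units; that floor lies within the scatter) and an at least 1.2-fold lower number from compound 2 to compound 3 (0.08 log units; that floor lies within the scatter), both floors that lie within the scatter. The step from compound 1 to compound 2 is a step that the two limits leave unreadable from compound 1 to compound 2.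

Compound 4 `CCC#CCOc1cccc2ccc(N)nc12` is not yet measured. It differs from compound 3 by but-1-yn-1-yl in place of 2-methylcyclopropyl on a saturated chain carbon bound to an oxygen on an aromatic ring. This is the reverse direction of the measured steps: a ring gives way to an unbranched chain carrying a triple bond, as in compound 2. The step from compound 2 to compound 3 bears most on it; its reversal suggests that compound 4 will show a higher number than compound 3, likely reaching the limit again, while the floors of both measured steps leave open that the change lies within the scatter. The expected step is a 1.6-fold higher number from compound 3 to compound 4 (0.20 log units; within the scatter). Compound 4 is estimated at 2600 nM, within 1200 nM to 6000 nM.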

Compound 4, half-maximal inhibitory concentration: > 2000 nM
Compound 4: only a limit was reported; the forecaster's own chance of this, stated with the estimate: 60%; the middle value lies beyond the limit too.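

In this assay compound 4 gives a limit of the assay rather than a number, so but-1-yn-1-yl joins the ethoxymethyl and but-2-yn-1-yl groups at the same limit: the limit of > 2000 nM in this assay, at which 3 of the 4 values shown sit.
Replacing 2-methylcyclopropyl with but-1-yn-1-yl, with the same count of heavy atoms, gives an at least 1.2-fold higher number from compound 3 to compound 4 (0.08 log units; that floor lies within the scatter), so a real loss on going from the ring to the unbranched chain is neither established nor excluded. The steps to compound 4 from compound 1 and from compound 2 cannot be read, as both ends of each are limits.

Going by these compounds, whether but-2-yn-1-yl and but-1-yn-1-yl differ at all stays open. The compounds shown also do not tell whether a side chain carrying an amine, or a plain cyclopropyl group, would give a lower number than compound 3.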